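Nitro in Place of Chloro: Expected Cytotoxicity of Compound 4

This account rests on a few compounds, and the source may have more. Where it says the series, first, only, none or still open, it means among the compounds named here.

Compound 1 `Cc1cc(C#N)cc(C)c1Oc1ccnc(SCC(=O)Nc2ccc(C#N)cc2)n1`: in an ADME assay on MT4 cells (Homo sapiens) for cytotoxicity, read by MTT assay, with a stated time of 4 days (on this read-out higher numbers stand for lower toxicity in this test and lower numbers for higher toxicity in this test), compound 1 gives > 300000 nM, which is a limit of the assay rather than a number.
Compound 2 `Cc1ccc(NC(=O)CS(=O)(=O)c2nccc(Oc3c(C)cc(C#N)cc3C)n2)cc1C`: compound 2 gives 13900 nM.
Compound 3 `Cc1cc(C#N)cc(C)c1Oc1ccnc(S(=O)(=O)CC(=O)Nc2cccc(Cl)c2)n1`: compound 3 gives 25400 nM.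

Compound 3 holds the higher of the two numbers, with compound 2 nearest; the step of a 1.8-fold higher number from compound 2 to compound 3 (0.26 log units; within the scatter) lies within the scatter. Compound 4 `Cc1cc(C#N)cc(C)c1Oc1ccnc(S(=O)(=O)CC(=O)Nc2cccc([N+](=O)[O-])c2)n1` differs from compound 3 only in nitro in place of chloro on an aromatic carbon. For the measured compounds named here, the one measured step that bears on this, a 1.8-fold higher number from compound 2 to compound 3 (0.26 log units; within the scatter), also exchanged the group on that ring and stayed within the scatter, so for compound 4 no step beyond the scatter is expected in this assay. Compound 4 is therefore estimated at 25000 nM, between 8000 nM and 80000 nM. That expectation amounts to a step of a 1.0-fold lower number from compound 3 to compound 4 (0.01 log units; within the scatter).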

Compound 4, half-maximal cytotoxic concentration: 23600 nM
Compound 4: middle estimate off by 1.1-fold (0.03 log units), on the high side; the range from low to high includes it.
By their numbers in this assay, from the lowest: compounds 2, 4 and 3 (each within the scatter of the next). At a limit, above all of these: compound 1.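

In this assay, nitro in place of chloro on an aromatic carbon gives a 1.1-fold lower number from compound 3 to compound 4 (0.03 log units; within the scatter), the first step shown that exchanges this one group and leaves the rest of the ring as it was. With 3-nitrophenyl in place of 3,4-dimethylphenyl, the result is a 1.7-fold higher number from compound 2 to compound 4 (0.23 log units; within the scatter), so all three ring patterns now lie within the scatter of one another. Nothing shown here bears on why these values lie so close. Going by these compounds, whether an amine or a carboxylic acid at this position would also stay within the scatter remains open, as does the outcome for a longer chain there.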